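Ring swap on the amide of a histamine H3 series

The compounds below may be only part of what the source reports. "The series", "measured", "known", "first", "only" and "open" are said of these compounds alone.

Of the compounds shown here, three sharing one core have been measured in an assay on CHO cells for displacement of a labelled ligand from histamine receptor H3 (Macaca mulatta); a lower number here means a stronger inhibitor, a higher number a weaker inhibitor. Compound 1 `Cc1cc(N2CCC(N3CCCC3C)C2)ccc1NC(=O)C1C(C)(C)C1(C)C` gives 37.3 nM. Compound 2 `Cc1cc(N2CC[C@H](N3CCC[C@@H]3C)C2)ccc1NC(=O)C1CCCO1` gives 7.33 nM. Compound 3 `Cc1cc(N2CC[C@H](N3CCC[C@@H]3C)C2)ccc1NC(=O)C1CCOCC1` gives 0.97 nM, the lowest of the three numbers; the step of a 7.6-fold lower number from compound 2 to compound 3 (0.88 log units; beyond the scatter) separates it from compound 2, and compound 1 lies further away still.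

Compound 4 `Cc1cc(N2CC[C@H](N3CCC[C@@H]3C)C2)ccc1NC(=O)C1C(C)(C)C1(C)C` differs from compound 3 in a single place: 2,2,3,3-tetramethylcyclopropyl in place of oxan-4-yl on a carbonyl carbon. Going by the values given here, only one measured step touches this position, the one from compound 2 to compound 3, and it shows that the ring on the carbonyl carbon can move the number well beyond the scatter. More directly, compound 1 carries the same 2,2,3,3-tetramethylcyclopropyl group as compound 4 and differs from it only in that its stereocentres are left undefined; compound 1 gives a number far higher than that of compound 3. The expected step of a 26-fold higher number from compound 3 to compound 4 (1.41 log units; beyond the scatter) is therefore a clear rise, towards the region where compound 1 sits, with room for the defined stereoisomer to come out somewhat better than the undefined one. The estimate for compound 4 in this assay is 25 nM, in the range 8 nM to 80 nM.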

Compound 4, inhibition constant: 0.55 nM
Compound 4: the middle estimate sits 45-fold (1.66 log units) above what was measured; measured number outside the range, below it.
By their numbers in this assay, from the lowest: compounds 4 and 3 (each within the scatter of the next); then compound 2; then compound 1.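

In this assay, 2,2,3,3-tetramethylcyclopropyl and oxan-4-yl on the carbonyl carbon cannot be told apart, with a 1.8-fold lower number from compound 3 to compound 4 (0.25 log units; within the scatter), so the hydrogen-bond acceptor counted in oxan-4-yl is not required for a number at this level. Only oxolan-2-yl stands apart among the defined stereoisomers, with a 13-fold lower number from compound 2 to compound 4 (1.12 log units; beyond the scatter), which means that the earlier step from compound 2 to compound 3 did not show a general gain from an oxygen-bearing six-membered ring. The weak number of compound 1 also turns out to say little about the tetramethylcyclopropyl group itself, since a 68-fold lower number from compound 1 to compound 4 (1.83 log units; beyond the scatter) arises with the same atoms and bonds, and the only thing separating the two is this: the fact that one of compounds 1 and 4 is drawn with a defined configuration and the other without, at the place where they differ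

The compounds shown do not tell which stereoisomers are present in compound 1 or how each of the other configurations would read, as only one defined configuration carries this group. They also leave open whether a ring with a basic amine, such as piperidin-4-yl, or an open chain, such as tert-butyl, would hold the number on the carbonyl carbon.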